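A few compounds are considered here, and "the series" means these few. Any claim that something is new, unique, unknown or untested is made for them only; others in the source may bear on it.

Working notes on the series, all read in a functional assay on KB cells (Homo sapiens) for cytotoxicity; a higher number here means that more compound is needed for the effect, a lower number that less compound is needed. On the shared core, compound 1 `COC1=C(C)C(=O)/C(=C(O)/C=C/c2ccccc2OC)C(=O)C1(C)C` gives 2.8 ug/mL, compound 2 `COC1=C(C)C(=O)/C(=C(O)/C=C/c2ccc(O)cc2)C(=O)C1(C)C` gives 3 ug/mL and compound 3 `COC1=C(C)C(=O)/C(=C(O)/C=C/c2ccc(F)cc2)C(=O)C1(C)C` gives 2.7 ug/mL. Compound 3 cannot be separated from either of the other two: a 1.0-fold lower number from compound 1 to compound 3 (0.02 log units; within the scatter) and a 1.1-fold lower number from compound 2 to compound 3 (0.05 log units; within the scatter) both stay within the scatter.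

The next compound is compound 4 `CCc1ccc(/C=C/C(O)=C2/C(=O)C(C)=C(OC)C(C)(C)C2=O)cc1`, reached through (ethyl in place of fluoro on an aromatic carbon). This puts ethyl in place of fluoro on an aromatic carbon, para to a large group, so 4-fluorophenyl becomes 4-ethylphenyl.

The closest measured step is a 1.1-fold lower number from compound 2 to compound 3 (0.05 log units; within the scatter), a swap on that same aromatic carbon. The changes of the whole aryl group, a 1.1-fold higher number from compound 1 to compound 2 (0.03 log units; within the scatter) and a 1.0-fold lower number from compound 1 to compound 3 (0.02 log units; within the scatter), also bear on it. All three are small and within the scatter, so the measured substituent swaps have so far left the number unmoved. Going by the values given here, none of the measured compounds carries ethyl, so that group itself is untested, and three compounds are a thin basis.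

The expectation therefore starts from compound 3 at 2.7 ug/mL, with no direction favoured. The estimated step is a 1.0-fold higher number from compound 3 to compound 4 (0.02 log units; within the scatter), expected to stay within the scatter. For compound 4 the expected value is 2.8 ug/mL, with an estimated range of 1.4 ug/mL to 5.5 ug/mL.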

Compound 4, concentration for half-maximal effect: 1.9 ug/mL
Compound 4: the middle estimate sits 1.5-fold (0.17 log units) above what was measured, within the range that was stated.
By their numbers in this assay, from the lowest: compounds 4, 3, 1 and 2 (each within the scatter of the next).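

In this assay, going by these compounds alone, the aromatic carbon para to a large group now carries an alkyl group, where the earlier compounds had only fluoro or hydroxy there. Ethyl cannot be separated from either of them at this position (a 1.4-fold lower number from compound 3 to compound 4 (0.15 log units; within the scatter); a 1.6-fold lower number from compound 2 to compound 4 (0.20 log units; within the scatter)), so tolerance at this carbon extends to a group with no hydrogen-bond donors or acceptors and no halogen. The change of the whole aryl group from 2-methoxyphenyl to 4-ethylphenyl also stays within the scatter (a 1.5-fold lower number from compound 1 to compound 4 (0.17 log units; within the scatter)), and no measurement shown here explains why these swaps leave the number unresolved.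

The four compounds shown do not reveal whether any group at this aromatic carbon can move the number beyond the scatter, and a carboxylic acid, an amine or a longer chain such as hexyl would test that over a wider range of substituents. As far as these compounds go, it also remains open whether the aryl group matters at all in this assay, and replacing the phenyl ring with a pyridine or a plain methyl group would address that question.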